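The compounds below may be only part of what the source reports. "The series", "measured", "known", "first", "only" and "open" are said of these compounds alone.

Three compounds share one core and differ only in the group on an amide-type nitrogen in a ring. In a physicochemical assay for solubility, read by turbidimetry, measured as kinetic solubility, at pH 7.4 (a lower number here means a less soluble compound, a higher number a more soluble compound), compound 1 `O=C(NCCCCc1ccccc1)c1cccc(C2SCC(=O)N2c2ccccn2)c1` gives 20000 nM. Compound 2 `O=C(NCCCCc1ccccc1)c1cccc(C2SCC(=O)N2c2cccc(F)c2)c1` gives 10000 nM in this assay, and compound 3 `COc1ccc(F)cc1N1C(=O)CSC1c1cccc(C(=O)NCCCCc2ccccc2)c1` gives 10000 nM in this assay. Compound 3 stands level with compound 2 on these numbers, the two together giving the lowest numbers of the three, with compound 1 the furthest away: a 2.0-fold lower number from compound 1 to compound 3 (0.30 log units; within the scatter), a step that lies within the scatter. Compound 4 `Cc1cccc(N2C(=O)CSC2c2cccc(C(=O)NCCCCc3ccccc3)c2)c1` is not yet measured; it differs from compound 3 in one place: 3-methylphenyl in place of 5-fluoro-2-methoxyphenyl on an amide-type nitrogen in a ring. Among the measured compounds shown here, three measured steps bear on this, each an exchange of the group on that nitrogen: a 2.0-fold lower number from compound 1 to compound 2 (0.30 log units; within the scatter), a 2.0-fold lower number from compound 1 to compound 3 (0.30 log units; within the scatter), no change at the digits printed from compound 2 to compound 3 (within the scatter). None of them left the scatter. A step beyond the scatter is therefore not expected, and the expected step is no change at the digits printed from compound 3 to compound 4 (within the scatter). Compound 4 is estimated at 10000 nM, in a range from 5000 nM to 20000 nM.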

Compound 4, solubility: 10000 nM
Estimate against measurement, compound 4: no gap at the digits printed; low and high end bracket the measured number.
By their numbers in this assay, from the lowest: compounds 2, 3, 4 and 1 (each within the scatter of the next).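

In this assay, the group on the amide-type nitrogen can now be carbon only: 3-methylphenyl in place of 5-fluoro-2-methoxyphenyl, which also takes the count of hydrogen-bond acceptors in this group from 1 to 0, gives no change at the digits printed from compound 3 to compound 4 (within the scatter). The closer exchange of methyl for fluoro on an aromatic carbon gives no change at the digits printed from compound 2 to compound 4 (within the scatter), and 3-methylphenyl in place of pyridin-2-yl gives a 2.0-fold lower number from compound 1 to compound 4 (0.30 log units; within the scatter), so all three new steps stay within the scatter. No measurement shown here explains this result.

Every group shown on this nitrogen is a six-membered aromatic ring, so the effect of an open-chain group, such as a butyl chain, is still unknown. Also open, on these data alone, is whether an aromatic ring carrying an amine or a carboxylic acid would step beyond the scatter.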